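This account rests on a few compounds, and the source may have more. Where it says the series, first, only, none or still open, it means among the compounds named here.

In a functional assay on PC-3 cells (Homo sapiens) for inhibition, read by MTT assay, with a stated time of 48 h, tested at 10 uM (on this read-out lower numbers stand for less inhibition of growth and higher numbers for more inhibition of growth at the one concentration tested), compound 1 `Cc1cc(=O)c2c(O)cc(OCc3ccco3)c([C@H]3CCN(C)C[C@H]3O)c2o1` gives 14%, compound 2 `Cc1oc2c([C@H]3CCN(C)C[C@H]3O)c(O)cc(O)c2c(=O)c1C(O)c1ccc([N+](=O)[O-])cc1` gives 24%, and compound 3 `Cc1oc2c([C@H]3CCN(C)C[C@H]3O)c(O)cc(O)c2c(=O)c1C(O)c1ccc(Cl)cc1` gives 41%, the highest of the three numbers. Compound 4 `Cc1oc2c([C@H]3CCN(C)C[C@H]3O)c(O)cc(O)c2c(=O)c1C(O)c1cccc(Cl)c1` is still unmeasured. It has the same atoms as compound 3, joined differently: 3-chlorophenyl in place of 4-chlorophenyl on a saturated chain carbon bound to an aromatic carbon and an oxygen on a saturated carbon. Among the measured compounds shown here, only one measured step touches this aryl group: a number 17 percentage points higher from compound 2 to compound 3 (beyond the scatter), a modest change with chloro in place of nitro on an aromatic carbon. For the measured compounds named here, that step swaps one group for another, and no measured pair shows what shifting the chlorine does. The expected result is therefore no change beyond the scatter, and the estimate is a number 5 percentage points lower from compound 3 to compound 4 (within the scatter). For compound 4 the estimated value is 36%, within a range from 22% to 50%.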

Compound 4, percent growth inhibition at one concentration: 31%
For compound 4 the middle estimate is 5 percentage points above the measured one; the measured number falls inside the stated range.
By their numbers in this assay, from the lowest: compounds 1, 2, 4 and 3 (each within the scatter of the next, the first and the last beyond it).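

In this assay the move of chlorine gives a number 10 percentage points lower from compound 3 to compound 4 (within the scatter) and so shows no clear difference between 4-chlorophenyl and 3-chlorophenyl on this carbon. The step from the nitro compound gives a number 7 percentage points higher from compound 2 to compound 4 (within the scatter) and so differs from the earlier chloro-for-nitro step, which lay beyond the scatter: 3-chlorophenyl does not clearly keep the separation from 4-nitrophenyl that 4-chlorophenyl showed. No available evidence accounts for this result. From the compounds shown here alone, whether an aminophenyl group or a plain phenyl group here would stand apart from these chlorophenyl groups remains open.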